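The compounds below may be only part of what the source reports. "The series", "measured", "known", "first", "only" and "open" are said of these compounds alone.

Of the compounds shown here, three on a shared core have been read so far in an ADME assay on MDBK cells (Bos taurus) for cytotoxicity, read by MTT assay, with a stated time of 72 h (a lower number here means that less compound is tolerated, a higher number that more compound is tolerated), and none has given a number. Compound 1 `Cc1ccc(NCc2cn(-c3ccccc3)nc2-c2ccc(Cl)cc2)cc1` gives > 100000 nM here, which is a limit of the assay. Compound 2 `Cc1ccc(NCc2cn(-c3ccccc3)nc2-c2ccc(C)cc2)cc1` gives > 100000 nM here, again a limit. Compound 3 `Clc1ccc(NCc2cn(-c3ccccc3)nc2-c2ccc(Cl)cc2)cc1` gives > 100000 nM too, so it also stands only at a limit. The series thus rests on the limit of > 100000 nM in this assay, at which 3 of the 3 values shown sit, and on nothing sharper.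

Compound 4 `Cc1ccc(-c2nn(-c3ccccc3)cc2CNc2ccc(Cl)cc2)cc1` differs from compound 3 by methyl in place of chloro on an aromatic carbon in one place, with methyl in place of chloro on an aromatic carbon, para to a large group, which reads as 4-chlorophenyl to 4-methylphenyl. The closest measured step is a step that the two limits leave unreadable from compound 1 to compound 2 with the same 4-chlorophenyl to 4-methylphenyl change. The other measured step, a step that the two limits leave unreadable from compound 1 to compound 3 with chloro in place of methyl on an aromatic carbon, lies elsewhere in the structure and bears on it less directly. Neither step has a readable size, but both ends of each sit at the limit. The step expected in this assay is accordingly none beyond the scatter, in either direction, and the estimate reads a number no higher from compound 3 to compound 4 (the limit leaves the size open) for now. For compound 4 the expected value is 100000 nM with an estimated range from 60000 nM to 150000 nM and a high expected chance that only a limit is reported.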

Compound 4, half-maximal cytotoxic concentration: > 100000 nM
Compound 4: a limit, no number; the forecaster's own chance of this, stated with the estimate: 90%; the middle value lies on the limit itself.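

In this assay compound 4 gives > 100000 nM, which is a limit of the assay, so its steps from compound 3 and from compound 2 cannot be read. The series still rests on one limit: the limit of > 100000 nM in this assay, at which 4 of the 4 values shown sit.

The compounds shown leave open at what concentration any of them would reach the half-maximal cytotoxic read-out, and whether exchanging chloro and methyl alters it.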